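Swapping Fluoro for Chloro in a Cytotoxicity Series

This account rests on a few compounds, and the source may have more. Where it says the series, first, only, none or still open, it means among the compounds named here.

Four close relatives of one amide are compared here, three of them already measured. Compound 1 `O=C(Nc1nc2ccc(F)cc2s1)c1cn(-c2ccccc2)nc1-c1ccccc1` was tested in a functional assay on A549 cells (Homo sapiens) for cytotoxicity, read by MTT assay, with a stated time of 72 h (a lower number here means a stronger inhibitor, a higher number a weaker inhibitor), where compound 1 gives 10200 nM. Compound 2 `O=C(Nc1nc2ccc(Cl)cc2s1)c1cn(-c2ccccc2)nc1-c1ccccc1` carries chloro in place of fluoro on an aromatic carbon; in this assay compound 2 gives 7670 nM, so that a 1.3-fold lower number from compound 1 to compound 2 (0.12 log units; within the scatter). Compound 3 `COc1ccc(-c2nn(-c3ccccc3)cc2C(=O)Nc2nc3ccc(F)cc3s2)cc1` keeps the fluoro of compound 1 and is altered elsewhere; in this assay compound 3 gives 7560 nM, so that a 1.3-fold lower number from compound 1 to compound 3 (0.13 log units; within the scatter). All three measured values sit within the scatter of one another, so none can be called stronger or weaker than the others.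

Compound 4 `COc1ccc(-c2nn(-c3ccccc3)cc2C(=O)Nc2nc3ccc(Cl)cc3s2)cc1` has not yet been measured. It is related to compound 3 by chloro in place of fluoro on an aromatic carbon. The place of this change reads word for word the same as for the change from compound 1 to compound 2, so it is the same change carried out on a second core. The two cores differ by methoxy in place of hydrogen on an aromatic carbon.

Because the earlier step of a 1.3-fold lower number from compound 1 to compound 2 (0.12 log units; within the scatter) stayed within the scatter, compound 4 is expected to show a step of about a 1.3-fold lower number from compound 3 to compound 4 (0.12 log units; within the scatter). For compound 4 the estimate in this assay is 5800 nM. For compound 4 the expected range runs from 2500 nM to 14000 nM.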

Compound 4, half-maximal inhibitory concentration: 4710 nM
For compound 4 the middle estimate is 1.2-fold (0.09 log units) above the measured one; measured number inside the range.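

Carried onto the core with the methoxy group, the change from 6-fluoro-1,3-benzothiazol-2-yl to 6-chloro-1,3-benzothiazol-2-yl in this assay gives a 1.6-fold lower number from compound 3 to compound 4 (0.21 log units; within the scatter), and this agrees with what the same change did on the core of compound 1: the same change on two cores in this assay, a 1.3-fold lower number (0.12 log units; within the scatter) from compound 1 to compound 2 and a 1.6-fold lower number (0.21 log units; within the scatter) from compound 3 to compound 4, 1.2-fold (0.08 log units) apart, within the scatter of two such steps. The methoxy change reads the same way on the chloro core, where it gives a 1.6-fold lower number from compound 2 to compound 4 (0.21 log units; within the scatter), and it too agrees with its earlier step: the same change on two cores in this assay, a 1.3-fold lower number (0.13 log units; within the scatter) from compound 1 to compound 3 and a 1.6-fold lower number (0.21 log units; within the scatter) from compound 2 to compound 4, 1.2-fold (0.08 log units) apart, within the scatter of two such steps. Across these four compounds, then, either change can be carried from one core to the other with no sign of a different outcome, but each step is small enough to be ordinary scatter, so the data show neither that either change truly alters the number nor that the two effects add up.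

The compounds shown leave open whether another group on that aromatic carbon, such as bromo, methyl or an amine, would give a step beyond the scatter. They also leave open whether a hydroxy group or a longer chain in place of the methoxy would shift the number enough for a real difference between cores to be seen.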